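The source may report more compounds than this note shows. Statements on the series, on what has been measured and on what is new or still open speak of the compounds shown alone.

Among the measured compounds shown here, in an ADME assay for permeability, using PAMPA, with a stated time of 4 h, at pH 7.4 (a lower number here means that the compound crosses the layer more slowly, a higher number that the compound crosses the layer faster), compound 2 `c1ccc2c(c1)CN[C@@H](CN(CC[C@H]1CCCNC1)[C@H]1CCCc3cccnc31)C2` gives 55 nm/s, the lowest of the three numbers measured so far: compound 1 `CN1CCN(CCCN(C[C@H]2Cc3ccccc3CN2)[C@H]2CCCc3cccnc32)CC1` gives 360 nm/s, and compound 3 `c1cnc2c(c1)CCC[C@@H]2N(CCCN1CCNCC1)Cc1nc2ccccc2[nH]1` gives 146 nm/s. Compound 4 `CCN1CCN(CCCN(C[C@H]2Cc3ccccc3CN2)[C@H]2CCCc3cccnc32)CC1` differs from compound 2 by (4-ethylpiperazin-1-yl)methyl in place of piperidin-3-yl on a saturated chain carbon, two bonds along the chain from an amine nitrogen. For the measured compounds named here, one measured step bears on this change, and it runs almost exactly in reverse: a 6.5-fold lower number from compound 1 to compound 2 (0.82 log units; beyond the scatter). Undoing that change, now with a (4-ethylpiperazin-1-yl)methyl rather than a (4-methylpiperazin-1-yl)methyl group, is therefore expected to raise the number by a comparable amount, so the step of a 7.3-fold higher number from compound 2 to compound 4 (0.86 log units; beyond the scatter) is estimated. For compound 4 the expected value in this assay is 400 nm/s, with a range from 180 nm/s to 850 nm/s.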

Compound 4, apparent permeability: 317 nm/s
Compound 4: middle estimate off by 1.3-fold (0.10 log units), on the high side; measured number inside the range.
By their numbers in this assay, from the lowest: compound 2; then compound 3; then compounds 4 and 1 (each within the scatter of the next).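

In this assay, the rise of a 5.8-fold higher number from compound 2 to compound 4 (0.76 log units; beyond the scatter) shows that a second piperazine group, (4-ethylpiperazin-1-yl)methyl, also stands well clear of piperidin-3-yl at this position, so the earlier gap did not rest on (4-methylpiperazin-1-yl)methyl alone. The extra methyl makes no readable difference, with a 1.1-fold lower number from compound 1 to compound 4 (0.06 log units; within the scatter) as the step between the two piperazine compounds. Nothing measured here explains either step. Still open, going by these compounds, is whether propyl in place of that ethyl, or (morpholin-4-yl)methyl in place of the whole group, would keep the number at this level.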